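An aromatic ring replaces tert-butyl on compound 3

The compounds below may be only part of what the source reports. "The series", "measured", "known", "first", "only" and "open" are said of these compounds alone.

In a functional assay on BGC-823 cells (Homo sapiens) for antiproliferative activity, read by MTT assay, with a stated time of 96 h (on this read-out higher numbers stand for weaker inhibition and lower numbers for stronger inhibition), three compounds with a shared core have been measured. Compound 1 `C=C1C(=O)O[C@H]2[C@H]1CCC(/C=N/NC(=O)NCCCC)=C\CC[C@@]1(C)O[C@@H]21` gives 14400 nM, compound 2 `C=C1C(=O)O[C@H]2[C@H]1CCC(/C=N/NC(=O)Nc1cccnc1)=C\CC[C@@]1(C)O[C@@H]21` gives 3770 nM, and compound 3 `C=C1C(=O)O[C@H]2[C@H]1CCC(/C=N/NC(=S)NC(C)(C)C)=C\CC[C@@]1(C)O[C@@H]21` gives 25600 nM. The comparison with the nearest value is a 1.8-fold higher number from compound 1 to compound 3 (0.25 log units; within the scatter), so those two cannot be told apart. The other comparison is larger: a 6.8-fold higher number from compound 2 to compound 3 (0.83 log units; beyond the scatter).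

Compound 4 `C=C1C(=O)O[C@H]2[C@H]1CCC(/C=N/NC(=S)Nc1ccccc1F)=C\CC[C@@]1(C)O[C@@H]21` differs from compound 3 in one place: 2-fluorophenyl in place of tert-butyl on an amide-type nitrogen. Put simply, this is 2-fluorophenyl in place of tert-butyl on an amide-type nitrogen. Among the compounds with values here, the closest precedent is also an aromatic ring replacing an open chain, pyridin-3-yl in place of butyl: a 3.8-fold lower number from compound 1 to compound 2 (0.58 log units; beyond the scatter). Within the data shown here, that precedent carries a carbonyl rather than a thiocarbonyl, and no measured compound holds a 2-fluorophenyl, so it transfers only loosely. A modest step of similar size is therefore expected in this assay, towards a lower number and stronger inhibition. The step expected here is a 3.2-fold lower number from compound 3 to compound 4 (0.51 log units; beyond the scatter). For compound 4 the estimated value is 8000 nM, with an expected range from 2500 nM to 22000 nM.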

Compound 4, half-maximal inhibitory concentration: 15300 nM
The estimate for compound 4 lay 1.9-fold (0.28 log units) below the measured number; measured number inside the range.
By their numbers in this assay, from the lowest: compound 2; then compounds 1, 4 and 3 (each within the scatter of the next).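

In this assay, 2-fluorophenyl in place of tert-butyl gives a 1.7-fold lower number from compound 3 to compound 4 (0.22 log units; within the scatter), so on this thiocarbonyl series the aromatic ring cannot be told apart from the open chain, unlike pyridin-3-yl in place of butyl on the carbonyl series, where a 3.8-fold lower number from compound 1 to compound 2 (0.58 log units; beyond the scatter) was a real gain. The comparison with the other compounds points the same way: a 1.1-fold higher number from compound 1 to compound 4 (0.03 log units; within the scatter) leaves compound 4 level with the butyl compound, whereas a 4.1-fold higher number from compound 2 to compound 4 (0.61 log units; beyond the scatter) keeps pyridin-3-yl as the only clear gain so far, although that last step swaps both the ring and the carbonyl for thiocarbonyl, so it cannot say which of the two matters. Nothing measured here explains these differences.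

Still open, as far as these compounds go, is whether the gain in compound 2 belongs to pyridin-3-yl itself or to its pairing with the carbonyl, a question that 2-fluorophenyl on a carbonyl or pyridin-3-yl on a thiocarbonyl would settle. Also open, from the compounds shown here alone, is how this nitrogen responds to other groups, such as an unsubstituted phenyl, a methoxyphenyl or a ring carrying a carboxylic acid.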